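The source may report more compounds than this note shows. Statements on the series, on what has been measured and on what is new or still open speak of the compounds shown alone.

In a functional assay on PC-3 cells (Homo sapiens) for inhibition (on this read-out higher numbers stand for weaker inhibition and lower numbers for stronger inhibition), compound 1 (`COc1cc2nc(N3CCN(S(=O)(=O)c4ccc(OC(F)(F)F)cc4)CC3)nc(N)c2cc1OC`) gives 25000 nM, the lowest of the three numbers recorded so far. Compound 2 (`COc1cc2nc(N3CCN(S(=O)(=O)c4cc(Cl)ccc4Cl)CC3)nc(N)c2cc1OC`) gives 60000 nM, and compound 3 (`COc1cc2nc(N3CCN(S(=O)(=O)c4cc(C(=O)O)c(Cl)cc4Cl)CC3)nc(N)c2cc1OC`) gives 52000 nM. Both measured steps away from compound 1 alter the aryl group on the sulfonyl sulfur: a 2.4-fold higher number from compound 1 to compound 2 (0.38 log units; beyond the scatter), and a 2.1-fold higher number from compound 1 to compound 3 (0.32 log units; beyond the scatter). Between the two dichlorophenyl compounds, a 1.2-fold lower number from compound 2 to compound 3 (0.06 log units; within the scatter). Compound 4 (`CCCCc1ccc(-c2ccc(S(=O)(=O)N3CCN(c4nc(N)c5cc(OC)c(OC)cc5n4)CC3)cc2)cc1`) is the unmeasured member of the set. Its change from compound 1 is 4-butylphenyl in place of trifluoromethoxy on an aromatic carbon, so the ring on the sulfonyl sulfur now carries a second six-membered aromatic ring of carbon only bearing a butyl chain. Within the data shown here, no measured step exchanges a substituent on that ring for an aromatic ring, so the two steps from compound 1 show only that altering this group moved this assay by a modest amount, in both cases toward a higher number. The step to compound 4 is therefore expected to be modest and without a firm direction, and the estimate corresponds to a 1.7-fold lower number from compound 1 to compound 4 (0.22 log units; within the scatter). Compound 4 is estimated at 15000 nM, with a range from 4000 nM to 60000 nM.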

Compound 4, half-maximal inhibitory concentration: 3400 nM
For compound 4 the middle estimate is 4.4-fold (0.64 log units) above the measured one; measured number outside the range, below it.
By their numbers in this assay, from the lowest: compound 4; then compound 1; then compounds 3 and 2 (each within the scatter of the next).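

In this assay, among these compounds, a 7.4-fold lower number from compound 1 to compound 4 (0.87 log units; beyond the scatter) is the first step at this aryl group on the sulfonyl sulfur that moves toward a lower number, whereas the steps from compound 1 to compounds 2 and 3 both moved toward a higher one. The change places 4-butylphenyl on an aromatic carbon, para to a large group, in place of trifluoromethoxy, so this position accepts a group of 10 carbon atoms with a further six-membered aromatic ring and still gives the lowest number of the four compounds. Nothing shown explains why this exchange lowers the number.

The entering group adds the aromatic ring and the butyl chain together, so the compounds shown do not tell how much of the step belongs to each; a plain phenyl group in the same place would separate the two. As far as these compounds go, it also remains open how the number responds to a chain of another length on that ring, such as a hexyl chain, or to an amine or a carboxylic acid at the end of the chain.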